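Nitrogen substituent variation on the shared core, aorta readout

This account rests on a few compounds, and the source may have more. Where it says the series, first, only, none or still open, it means among the compounds named here.

Measured so far:
compound 1 `COc1ccc(Cc2nn(C(C)(C)C)c(=O)c3ccccc23)cc1OC` — 10000 nM
compound 2 `Cn1nc(Cc2ccc3ccccc3c2)c2ccccc2c1=O` — > 10000 nM (a limit of the assay)
compound 3 `C=CCn1nc(Cc2ccc(Cl)cc2)c2ccccc2c1=O` — 2600 nM

Three compounds have been run in a functional assay on aorta with Alpha-1D adrenergic receptor (Rattus norvegicus) as the target; a lower number here means that less compound is needed, a higher number that more compound is needed for the effect. Compound 1 gives 10000 nM, the higher of the two numbers available. Compound 3 gives 2600 nM, the nearest value to compound 1, and the gap between them lies beyond the scatter. Compound 2 gives only a limit, > 10000 nM, so no number is known for it. This is the limit of > 10000 nM in this assay, at which 1 of the 3 values shown sits.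

Compound 4 `CCCCn1nc(Cc2ccc(OC)c(OC)c2)c2ccccc2c1=O` has not been measured. It differs from compound 1 by butyl in place of tert-butyl on an aromatic nitrogen. Among the compounds with values here, no pair of measured compounds shows this change, so no measured step guides the expectation. The step from compound 1 to compound 4 is expected to be small, within the scatter, estimated as a 1.1-fold lower number from compound 1 to compound 4 (0.05 log units; within the scatter). Compound 4 is therefore expected to give about 9000 nM, within a range from 3000 nM to 27000 nM. Compound 1 already gives 10000 nM, so a high reading for compound 4 would not be surprising.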

Compound 4, half-maximal effective concentration: 5400 nM
Compound 4: middle estimate off by 1.7-fold (0.22 log units), on the high side, within the range that was stated.
By their numbers in this assay, from the lowest: compound 3; then compounds 4 and 1 (each within the scatter of the next).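

In this assay, within the data shown here, this pair gives the first step that can be read at this nitrogen position: butyl in place of tert-butyl on an aromatic nitrogen gives a 1.9-fold lower number from compound 1 to compound 4 (0.27 log units; within the scatter). In this pair, the two arrangements of the same count of carbon atoms are not separated beyond the scatter, so this change alone gives no clear difference on the shared core. Compound 1 stands at the same number as the limit in this series, which places this pair near the top of the range that can be read: the limit of > 10000 nM in this assay, at which 1 of the 4 values shown sits.

Compounds 2 and 3 differ from compound 1 in more than one place, so steps to them cannot be read. From the compounds shown here alone, it remains open how a longer chain ending in an amine or a carboxylic acid on this nitrogen would read with the rest of compound 4 kept.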